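Saturating a Vinyl Group: Cytotoxicity Outlook for Compound 3

The source may hold more compounds than are shown below. What is called first, only, known or untested is meant among the compounds shown, and "the series" means these compounds.

Measured compounds:
- compound 1, `C=Cc1ccsc1CN[C@@H]1C[C@H]2C[C@@H]([C@H]1C)C2(C)C`: 50000 nM
- compound 2, `C[C@H]1[C@H](NCc2cc(-c3ccsc3)cs2)C[C@H]2C[C@@H]1C2(C)C`: 25000 nM

Of the compounds shown here, two have been tested in an ADME assay on MDCK cells (Canis lupus familiaris) for cytotoxicity, read by microscopy, with a stated time of 48 h; on this read-out lower numbers stand for higher toxicity in this test and higher numbers for lower toxicity in this test. In this assay compound 1 gives 50000 nM, and compound 2 gives 25000 nM. Within the data shown here, the gap between these two numbers lies within the usual scatter of repeated measurements, so neither compound can be set apart from the other on this read-out, and no structural step between them is given.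

The compound still to be measured is compound 3, `CCc1ccsc1CN[C@@H]1C[C@H]2C[C@@H]([C@H]1C)C2(C)C`. It differs from compound 1 in one place: ethyl in place of vinyl on an aromatic carbon

Nothing in the measured pair speaks to this kind of change. With so little to go on, the expectation is that the step from compound 1 to compound 3 stays within the scatter, in no particular direction. Compound 3 is therefore estimated at 50000 nM, with a plausible range from 25000 nM to 100000 nM, meaning an expected step of no change at the digits printed from compound 1 to compound 3 (within the scatter).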

Compound 3, minimum cytotoxic concentration: 25000 nM
Beside the measured number, compound 3's estimate is 2.0-fold (0.30 log units) above it; the range from low to high includes it.
By their numbers in this assay, from the lowest: compounds 2, 3 and 1 (each within the scatter of the next).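

In this assay, putting ethyl in place of vinyl on an aromatic carbon gives a 2.0-fold lower number from compound 1 to compound 3 (0.30 log units; within the scatter). Among these compounds, this is the first direct test of a change at this position, on the five-membered aromatic ring with 1 sulfur. Here, removing the double bond outside aromatic rings while keeping both carbons leaves compound 1 and compound 3 impossible to tell apart on this read-out. No separate measurement is available that could explain this result.

Among the compounds shown here, the pair covers only two small carbon groups, so it remains open whether a longer chain such as butyl, or a group containing other atoms such as an amine or a carboxylic acid, would also stay within the scatter here. Going by these compounds, it also remains open whether the same swap would behave alike elsewhere on the shared core.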